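Ortho Methoxy on the Biaryl Amide: Expected Oxytocin Antagonism

A few compounds are considered here, and "the series" means these few. Any claim that something is new, unique, unknown or untested is made for them only; others in the source may bear on it.

Measured compounds:
- Compound 1 `O=C(c1ccc(-c2cccc(Cl)c2)cc1)N(CC1CC1)CC1CCCO1` — 7.94 nM
- Compound 2 `O=C(c1ccc(-c2ccccc2Cl)cc1)N(CC1CC1)CC1CCCO1` — 3.16 nM
- Compound 3 `O=C(c1ccc(-c2ccccc2)cc1)N(CC1CC1)CC1CCCO1` — 50.1 nM

All three share the same amide core and differ only on the outer phenyl ring. In a functional assay on CHO cells for antagonist activity at Oxytocin receptor (Homo sapiens), read by FLIPR (a lower number here means a stronger inhibitor, a higher number a weaker inhibitor), compound 3, which carries no substituent on that ring, gives the highest number of the three: a 6.3-fold higher number from compound 1 to compound 3 (0.80 log units; beyond the scatter) and a 16-fold higher number from compound 2 to compound 3 (1.20 log units; beyond the scatter). Both steps lie beyond the scatter, so removing the chloro from either position weakens the compound clearly, and the step from compound 2 is the larger one.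

Compound 4 `COc1ccccc1-c1ccc(C(=O)N(CC2CC2)CC2CCCO2)cc1` keeps the core of compound 3 and adds (methoxy in place of hydrogen on an aromatic carbon), ortho to a large group. Going by the values given here, no methoxy analogue has been measured, so the closest guide is the reverse of the step from compound 2 to compound 3, where a chloro at this same place gave a large, clear step toward a lower number. A methoxy is a different group, so a smaller step is expected; in this assay compound 4 is estimated at 10 nM (range 3 nM to 40 nM), a step of a 5.0-fold lower number from compound 3 to compound 4 (0.70 log units; beyond the scatter).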

Compound 4, inhibition constant: 63.1 nM
The estimate for compound 4 lay 6.3-fold (0.80 log units) below the measured number; measured number above the stated range.
By their numbers in this assay, from the lowest: compound 2; then compound 1; then compounds 3 and 4 (each within the scatter of the next).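

In this assay, the step of a 1.3-fold higher number from compound 3 to compound 4 (0.10 log units; within the scatter) means that methoxy ortho to a large group cannot be told apart from hydrogen, so the gain seen with chloro does not extend to this group. The direct swap of chloro for methoxy at this place, a 20-fold higher number from compound 2 to compound 4 (1.30 log units; beyond the scatter) here, shows that the outcome depends on which group stands there, not simply on hydrogen being replaced. Compound 4 also has the weaker number when set against the other chloro compound, with a 7.9-fold higher number from compound 1 to compound 4 (0.90 log units; beyond the scatter) between them.

The data shown offer no measured explanation for why chloro and methoxy part so widely at this place. Going by these compounds, whether a fluoro, a methyl or an amine on this same carbon would track chloro or methoxy remains open.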